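The source may hold more compounds than are shown below. What is called first, only, known or untested is meant among the compounds shown, and "the series" means these compounds.

In a functional assay on the whole organism (Gastrocnemius, strain Sprague-Dawley) for inhibition, with Rattus norvegicus as the target (on this read-out higher numbers stand for an effect only at larger amounts of compound and lower numbers for an effect already at smaller amounts), compound 2 (`O=C1NC(=O)N(/N=C/c2ccc(-c3ccc([N+](=O)[O-])cc3)o2)C1O`) gives 0.015 umol/kg and compound 1 (`O=C1NC(=O)N(/N=C/c2ccc(-c3ccc(Cl)cc3)o2)C1O`) gives 0.016 umol/kg, so the two stand level within the scatter. Compound 3 (`O=C1NC(=O)N(/N=C/c2ccc(-c3ccc(F)cc3)o2)C1O`) carries fluoro in place of nitro on an aromatic carbon, para to a large group: fluoro in place of nitro on an aromatic carbon. Within the data shown here, the only measured step at this place, nitro in place of chloro, is a 1.1-fold lower number from compound 1 to compound 2 (0.03 log units; within the scatter), and it stays within the scatter. On that single step, no change beyond the scatter is expected in this assay. The estimated step is a 1.2-fold higher number from compound 2 to compound 3 (0.08 log units; within the scatter). The estimated value for compound 3 is 0.018 umol/kg, with an expected range of 0.007 umol/kg to 0.045 umol/kg.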

Compound 3, dose for half-maximal effect: 0.091 umol/kg
The estimate for compound 3 lay 5.1-fold (0.70 log units) below the measured number; the whole stated range lies below it.
By their numbers in this assay, from the lowest: compounds 2 and 1 (each within the scatter of the next); then compound 3.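

In this assay the change to fluoro reads a 6.1-fold higher number from compound 2 to compound 3 (0.78 log units; beyond the scatter) and a 5.7-fold higher number from compound 1 to compound 3 (0.75 log units; beyond the scatter) and both steps lie beyond the scatter, while nitro and chloro stand level. This place on the six-membered aromatic ring therefore does respond to its substituent, which the step between nitro and chloro alone did not show. The level standing of those two does not extend to fluoro.

Going by these compounds, whether an amine or a methoxy group at this place would stand with nitro and chloro or with fluoro remains open. Nothing available accounts for the gap between fluoro and the other two groups.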